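The source may report more compounds than this note shows. Statements on the series, on what has been measured and on what is new or still open speak of the compounds shown alone.

Compound 1 `O=C(Nc1ccc(Br)cc1)Nc1ccc(Nc2ncnc3[nH]ncc23)cc1` gives in an assay on isolated protein for inhibition of vascular endothelial growth factor receptor 2 (Danio rerio), read by fluorescence and microscopy, with a stated time of 33 h (a higher number here means a weaker inhibitor, a lower number a stronger inhibitor), a value of > 100000 nM, which is a limit of the assay and not a number. Compound 2 `COc1cccc(NC(=O)Nc2ccc(Oc3ncnc4[nH]ncc34)cc2)c1` gives in this assay a value of 82000 nM.

Going by the values given here, compound 2 therefore holds the only numerical result in this assay; the other value sits at the limit of > 100000 nM in this assay, at which 1 of the 2 values shown sits, and tells only that compound 1 was not quantifiable there. Neither compound 1 nor compound 2 inhibits strongly.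

Compound 3 `O=C(Nc1ccc(Oc2ncnc3[nH]ncc23)cc1)Nc1ccc(C(F)(F)F)cc1` has not yet been measured in this assay. It differs from compound 2 in one place: 4-(trifluoromethyl)phenyl in place of 3-methoxyphenyl on an amide-type nitrogen, a 4-(trifluoromethyl)phenyl in place of a 3-methoxyphenyl on the amide-type nitrogen of the urea. Among the compounds with values here, no measured pair in this set reports such a step, so its size can only be estimated. Given that compound 2 itself gives 82000 nM, the expectation is a step of modest size, a 2.1-fold lower number from compound 2 to compound 3 (0.31 log units; beyond the scatter), toward somewhat stronger inhibition, with a real chance of no change beyond the scatter. Compound 3 is accordingly expected to give about 40000 nM, in the range 8000 nM to 150000 nM.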

Compound 3, half-maximal inhibitory concentration: 1200 nM
For compound 3 the middle estimate is 33-fold (1.52 log units) above the measured one; measured number below the stated range.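

In this assay, the aryl group on the amide-type nitrogen of the urea proves to be a strong lever on inhibition: replacing 3-methoxyphenyl with 4-(trifluoromethyl)phenyl gives a 68-fold lower number from compound 2 to compound 3 (1.83 log units; beyond the scatter), a step well beyond the scatter. The earlier compounds shown here showed only weak inhibition and no readable step, so they could not show whether a change at this place would move the result at all, whereas compound 3 shows that a single exchange there can do so without any change to the shared core. The change removes the methoxy group and brings in the trifluoromethyl group at a different ring position in one step, and nothing given here offers a measured property that would account for the result.

As far as these compounds go, whether the gain belongs to the trifluoromethyl group itself or to where it sits on the ring remains open, as does what an unsubstituted phenyl, a chlorine or a nitrile on that ring would give. Compound 1 differs from compound 3 in more than one place and adds no readable step, and its value is a limit of the assay and not a number: the limit of > 100000 nM in this assay, at which 1 of the 3 values shown sits.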